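The compounds below may be only part of what the source reports. "The series", "measured", "known", "first", "only" and "open" are said of these compounds alone.

Measured so far:
- compound 1, `Oc1ccccc1-c1cc(-c2cccs2)cc(-c2ccccc2O)n1`: an assay on isolated protein for inhibition of DNA topoisomerase 1 (Homo sapiens), with a stated time of 30 min, tested at 20 uM (a lower number here means a weaker effect, a higher number a stronger effect of the compound at the concentration tested), 0.2%
- compound 2, `Oc1cccc(-c2cc(-c3cccs3)cc(-c3ccccc3O)n2)c1`: 1.5%
- compound 3, `Oc1ccc(-c2cc(-c3cccs3)cc(-c3ccccc3O)n2)cc1`: 2%

All three numbers are low and lie close together. Compound 3 gives the highest of the three, but the steps of a number 0.5 percentage points higher from compound 2 to compound 3 (within the scatter) and a number 1.8 percentage points higher from compound 1 to compound 3 (within the scatter) both lie within the usual scatter, so nothing separates compound 3 from the other two beyond it, and it cannot be called the most active of the set.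

Compound 4, `Oc1ccc(-c2cc(-c3cccs3)cc(-c3cccc(O)c3)n2)cc1`, is the next member. It differs from compound 3 as follows: 3-hydroxyphenyl in place of 2-hydroxyphenyl on an aromatic carbon

The same kind of exchange is already seen once in the series, in the step of a number 1.3 percentage points higher from compound 1 to compound 2 (within the scatter), and the related exchanges a number 1.8 percentage points higher from compound 1 to compound 3 (within the scatter) and a number 0.5 percentage points higher from compound 2 to compound 3 (within the scatter) are of the same order. None of these moved the read-out beyond the scatter. The present change is therefore not expected to produce a step beyond the scatter in this assay, in either direction.

For compound 4 the expected read-out is 2%, with a range from 0% to 8%. The step from compound 3 that this estimate implies is no change at the digits printed from compound 3 to compound 4 (within the scatter), which is expected to be no more than scatter.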

Compound 4, a percentage reported as inhibition, at one concentration (the size of the read-out at that concentration, not a potency): 1.1%
Compound 4: middle estimate off by 0.9 percentage points, on the high side, within the range that was stated.
By their numbers in this assay, from the lowest: compounds 1, 4, 2 and 3 (each within the scatter of the next).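

In this assay, the exchange of 2-hydroxyphenyl for 3-hydroxyphenyl next to the ring nitrogen can now be read on a core carrying a 4-hydroxyphenyl group, where it gives a number 0.9 percentage points lower from compound 3 to compound 4 (within the scatter), and it behaves as it did on the core of compound 1: the same change on two cores in this assay, a number 1.3 percentage points higher (within the scatter) from compound 1 to compound 2 and a number 0.9 percentage points lower (within the scatter) from compound 3 to compound 4, 2.2 percentage points apart, within the scatter of two such steps. The exchange of 2-hydroxyphenyl for 4-hydroxyphenyl can also be read a second time, where it gives a number 0.4 percentage points lower from compound 2 to compound 4 (within the scatter), and the two cores again do not separate: the same change on two cores in this assay, a number 1.8 percentage points higher (within the scatter) from compound 1 to compound 3 and a number 0.4 percentage points lower (within the scatter) from compound 2 to compound 4, 2.2 percentage points apart, within the scatter of two such steps. Across the steps shown, moving the hydroxy group around these phenyl rings gives no step beyond the scatter, on either core, and no compound stands apart from the others.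

The compounds shown carry only hydroxyphenyl groups at this position, which leaves open whether an aminophenyl or a carboxyphenyl group there, or an amine-bearing chain in place of the thiophen-2-yl group, would give a step beyond the scatter in this assay. A read-out at one concentration also leaves the potency of all these compounds open.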